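This account rests on a few compounds, and the source may have more. Where it says the series, first, only, none or still open, it means among the compounds named here.

Going by the values given here, in a functional assay for inhibition, with Homo sapiens as the target (a lower number here means a stronger inhibitor, a higher number a weaker inhibitor), three compounds sharing one core have numbers so far. Compound 1 `COc1ccccc1C(=O)/C=C/c1ccccc1`, with methoxy, gives 2230 nM. Compound 2 `O=C(/C=C/c1ccccc1)c1ccccc1C(F)(F)F`, with trifluoromethyl, gives 748 nM. Compound 3 `CN(C)c1ccccc1C(=O)/C=C/c1ccccc1`, with dimethylamino, gives 1770 nM. That value stands close to the methoxy result, at a 1.3-fold lower number from compound 1 to compound 3 (0.10 log units; within the scatter), and apart from the trifluoromethyl result, at a 2.4-fold higher number from compound 2 to compound 3 (0.37 log units; beyond the scatter).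

Among the compounds with values here, the next structure is compound 4 `O=C(/C=C/c1ccccc1)c1ccccc1NS(=O)(=O)C(F)(F)F`, which has no measurement yet. It has ((trifluoromethyl)sulfonyl)amino in place of dimethylamino on an aromatic carbon, ortho to a large group: ((trifluoromethyl)sulfonyl)amino in place of dimethylamino on an aromatic carbon. Within the data shown here, no measured step tests this group directly, so the evidence is indirect. The largest step at this carbon is a 3.0-fold lower number from compound 1 to compound 2 (0.47 log units; beyond the scatter), which is modest, and the entering group also contains trifluoromethyl, the group of compound 2 at 748 nM. That shared name is weak support, but it points toward a lower number. In this assay, a small step in that direction is therefore expected, one that may not clear the scatter. The expected step is a 1.6-fold lower number from compound 3 to compound 4 (0.21 log units; within the scatter). Compound 4 is estimated at 1100 nM, with an expected range of 350 nM to 3000 nM.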

Compound 4, half-maximal inhibitory concentration: 5850 nM
For compound 4 the middle estimate is 5.3-fold (0.73 log units) below the measured one; measured number above the stated range.
By their numbers in this assay, from the lowest: compound 2; then compounds 3 and 1 (each within the scatter of the next); then compound 4.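

In this assay, ((trifluoromethyl)sulfonyl)amino on this aromatic carbon, ortho to a large group, makes compound 4 the weakest inhibitor of the four, with a 3.3-fold higher number from compound 3 to compound 4 (0.52 log units; beyond the scatter), a 2.6-fold higher number from compound 1 to compound 4 (0.42 log units; beyond the scatter) and a 7.8-fold higher number from compound 2 to compound 4 (0.89 log units; beyond the scatter), each step going the same way. The earlier compounds had shown this position moving by no more than a 3.0-fold lower number from compound 1 to compound 2 (0.47 log units; beyond the scatter), so the new group shows that the position can also shift the number upward, and over a wider span than the earlier groups covered; it also shows that containing trifluoromethyl does not carry over the low number of compound 2, since compounds at the two ends of the series both contain it. The data shown include no measurement that accounts for this reversal.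

Going by these compounds, what remains open is which part of the entering group goes with the higher number, since a plain amine, an acetylamino group or a methylsulfonylamino group at this carbon would separate the sulfonyl, the amino hydrogen and the trifluoromethyl. A carboxylic acid or a fluorine atom at the same place would also show how far the series extends in either direction.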